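From compound 2 to compound 4: one added methyl

The source may report more compounds than this note shows. Statements on the series, on what has been measured and on what is new or still open speak of the compounds shown alone.

Compound 1 `C/C(=C/C(=O)O)C(=O)c1ccccc1` gives 1.69
Compound 2 `C/C(=C\C(=O)O)C(=O)c1ccccc1` gives 2.44
Compound 3 `O=C(O)/C=C/C(=O)c1cccnc1` gives 0.26

In a physicochemical assay for lipophilicity (on this read-out higher numbers stand for higher lipophilicity and lower numbers for lower lipophilicity), compound 2 stands highest of the three, and both gaps to it lie beyond the scatter. Compound 1 is its nearest neighbour, and compound 3, at 0.26 on this scale, is the furthest from it. For the measured compounds named here, the one measured step runs a number 0.75 log units higher from compound 1 to compound 2 (beyond the scatter) and is modest yet beyond the scatter. That step goes with the fact that compounds 1 and 2 differ only in the configuration as drawn and says nothing direct about a new group.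

Compound 4 `C/C(=C\C(=O)O)C(=O)c1ccc(C)cc1` differs from compound 2 by one change, methyl in place of hydrogen on an aromatic carbon that is, methyl in place of hydrogen on an aromatic carbon. It keeps the double bond as drawn in compound 2. Going by the values given here, no measured step involves such a change, so the configuration step offers only a sense of scale. The expectation therefore starts from compound 2 at 2.44 and otherwise rests on the structural change alone. An upward step in this assay is expected, somewhat smaller than the configuration step, and it is estimated as a number 0.51 log units higher from compound 2 to compound 4 (beyond the scatter) for this single change. For compound 4 the estimated value is 2.95 with an expected range from 2.6 to 3.3 on this scale.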

Compound 4, partition coefficient: 2.94
For compound 4 the middle estimate is 0.01 log units above the measured one; the range from low to high includes it.
By their numbers in this assay, from the lowest: compound 3; then compound 1; then compound 2; then compound 4.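

In this assay the number runs a number 0.50 log units higher from compound 2 to compound 4 (beyond the scatter), so the aromatic carbon para to a group of 8 heavy atoms is a place where a single added carbon moves the read-out beyond the scatter. For the compounds shown here, until now the only measured step was a change of configuration, a number 0.75 log units higher from compound 1 to compound 2 (beyond the scatter), and this is the first step that comes from a change of substituent, with the double bond kept as drawn in compound 2 and the step likewise modest in size. Nothing at hand bears on why methyl in place of hydrogen at this place gives a step of this size.

The compounds shown leave open whether the step would continue in the same direction or change in size with an ethyl, a methoxy, an amine or a carboxylic acid on that same aromatic carbon. They also leave open whether methyl on another carbon of the ring, or methyl at this place with the double bond drawn as in compound 1, would give a step like this one.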